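A few compounds are considered here, and "the series" means these few. Any claim that something is new, unique, unknown or untested is made for them only; others in the source may bear on it.

Measured so far:
compound 1 `CCCCCc1cc(C(C)=O)c(O)cc1OCCCCC#N` gives 31%
compound 2 `CCc1cc(C(C)=O)c(O)cc1OCCCC(C)(C)C(N)=O` gives 92%
compound 3 `C=CCc1cc(C(C)=O)c(O)cc1OCCCCCC(=O)OC` gives 106%

In an assay on isolated protein for inhibition of leukotriene B4 receptor 1 (Homo sapiens), tested at 10 uM (a lower number here means less inhibition, a higher number more inhibition at the concentration tested (going by the name of the read-out)), compound 2 stands second highest of the three numbers. Its nearest neighbour is compound 3, whose number is higher and beyond the scatter; furthest is compound 1, whose number is lower and well beyond the scatter. For the measured compounds named here, no pair of measured compounds differs in one place only, so no single step is known here.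

Compound 4 `CCc1cc(C(C)=O)c(O)cc1OCCCCCCc1nnn[nH]1` differs from compound 2 in one place: 3-(1H-tetrazol-5-yl)propyl in place of 1-carbamoyl-1-methylethyl on a saturated chain carbon, three bonds along the chain from an oxygen on an aromatic ring. Both groups carry a hydrogen-bond donor, and the two measured compounds with a longer polar chain end sit high in this assay, so the expected step of a number 7 percentage points lower from compound 2 to compound 4 (within the scatter) is small, within the scatter or slightly downward. Compound 4 is therefore expected at 85%, in the range 55% to 105%.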

Compound 4, a percentage reported as inhibition, at one concentration (the size of the read-out at that concentration, not a potency): 91%
Compound 4: middle estimate off by 6 percentage points, on the low side; the range from low to high includes it.
By their numbers in this assay, from the lowest: compound 1; then compounds 4 and 2 (each within the scatter of the next); then compound 3.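

In this assay, 3-(1H-tetrazol-5-yl)propyl in place of 1-carbamoyl-1-methylethyl on a saturated chain carbon gives a number 1 percentage points lower from compound 2 to compound 4 (within the scatter). For the compounds shown here, this is the only single step available, and at this place a chain end with a five-membered aromatic ring and one with no ring cannot be told apart at the concentration tested. Nothing on hand bears on why the two read alike. Open, from the compounds shown here alone, is whether a carboxylic acid or an amine at this chain end would hold the number. A reading at one concentration also leaves open whether compound 2 and compound 4 differ in potency.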